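Aryl swap at the olefin carbon of the shared core

The source may hold more compounds than are shown below. What is called first, only, known or untested is meant among the compounds shown, and "the series" means these compounds.

Compound 1 `CC/C(=C(/c1ccc(/C=C/C(=O)O)cc1)c1cc2ccccc2[nH]1)c1ccccc1C` gives 33 nM in a functional assay on MCF7 cells (Homo sapiens) for inhibition; on this read-out higher numbers stand for weaker inhibition and lower numbers for stronger inhibition. Compound 2 `CC/C(=C(/c1ccc(/C=C/C(=O)O)cc1)c1cc2ccccc2[nH]1)c1ccc(OC)cc1` gives 61 nM in this assay, and the step of a 1.8-fold higher number from compound 1 to compound 2 (0.27 log units; within the scatter) shows the two compounds lying within the scatter of each other. Compound 3 `CC/C(=C(/c1ccc(/C=C/C(=O)O)cc1)c1cc2ccccc2[nH]1)c1cccc(F)c1C#N` carries the change (2-cyano-3-fluorophenyl in place of 4-methoxyphenyl on a double-bonded chain carbon bound to a double-bonded chain carbon and a saturated chain carbon). Among the measured compounds shown here, only the step from compound 1 to compound 2 bears on this exchange, and it stayed within the scatter, so the step of a 1.2-fold lower number from compound 2 to compound 3 (0.09 log units; within the scatter) is expected to remain modest. Compound 3 is therefore estimated at 50 nM, within a range from 15 nM to 170 nM.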

Compound 3, half-maximal inhibitory concentration: 40 nM
Estimate against measurement, compound 3: 1.3-fold (0.10 log units) above; the measured number falls inside the stated range.
By their numbers in this assay, from the lowest: compounds 1, 3 and 2 (each within the scatter of the next).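

With the 2-cyano-3-fluorophenyl group on this double-bonded chain carbon, the exchange for 4-methoxyphenyl gives a 1.5-fold lower number from compound 2 to compound 3 (0.18 log units; within the scatter), and the exchange for 2-methylphenyl gives a 1.2-fold higher number from compound 1 to compound 3 (0.08 log units; within the scatter). All three phenyl groups, now including one that carries a nitrile and a fluorine, therefore lie within the scatter of each other in this assay. Nothing available explains this result. Still open, from the compounds shown here alone, is whether an amine, a carboxylic acid or a longer chain at this carbon, in place of the phenyl groups, would keep the numbers in this range.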